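A few compounds are considered here, and "the series" means these few. Any claim that something is new, unique, unknown or untested is made for them only; others in the source may bear on it.

Measured compounds:
- compound 1 `Cc1ccc(S(=O)(=O)c2cnc3cc(F)ccc3c2-c2ccc(F)cc2)cc1C`: 9.25 mL/min
- compound 2 `COc1ccc(S(=O)(=O)c2cnc3cc(F)ccc3c2-c2ccc(Cl)cc2)cc1`: 1.28 mL/min
- compound 3 `COc1cccc(-c2c(S(=O)(=O)c3ccc(C)c(C)c3)cnc3cc(F)ccc23)c1`: 8.78 mL/min

In an ADME assay on microsomes from liver (Homo sapiens) for metabolic stability, tested at 2.5 uM (on this read-out lower numbers stand for slow clearance and higher numbers for fast clearance), compound 1 gives 9.25 mL/min, the highest of the three numbers. Compound 3 stands nearest to it: a 1.1-fold lower number from compound 1 to compound 3 (0.02 log units; within the scatter). Compound 2 stands furthest away and gives 1.28 mL/min; it differs from compound 1 in two places, on the sulfonyl sulfur and on the other aryl ring, so its two values alone do not tell which place matters.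

Compound 4 `O=S(=O)(c1cc(Cl)cc(Cl)c1)c1cnc2cc(F)ccc2c1-c1ccc(F)cc1` differs from compound 1 in a single place: 3,5-dichlorophenyl in place of 3,4-dimethylphenyl on a sulfonyl sulfur

Going by the values given here, no measured step touches the group on the sulfonyl sulfur. Among the compounds with values here, the one step available, a 1.1-fold lower number from compound 1 to compound 3 (0.02 log units; within the scatter), changes the other aryl ring and lies within the scatter, so it gives no direct guide. Within the data shown here, the only hint is that compound 2, which also carries a different group on the sulfonyl sulfur, gives 1.28 mL/min. On that thin basis compound 4 is expected to show a somewhat lower number in this assay, with wide uncertainty. For compound 4 the expected step is a 2.3-fold lower number from compound 1 to compound 4 (0.36 log units; beyond the scatter). Compound 4 is therefore estimated at 4 mL/min, with a range from 1.5 mL/min to 9.5 mL/min.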

Compound 4, intrinsic clearance in a liver preparation (reported as CLH), per the amount of preparation that the assay uses: 0.18 mL/min
For compound 4 the middle estimate is 22-fold (1.35 log units) above the measured one, outside the stated range (below it).
By their numbers in this assay, from the lowest: compound 4; then compound 2; then compounds 3 and 1 (each within the scatter of the next).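

Going by these compounds alone, exchanging 3,4-dimethylphenyl for 3,5-dichlorophenyl on the sulfonyl sulfur gives a 51-fold lower number from compound 1 to compound 4 (1.71 log units; beyond the scatter) in this assay, so this position can move the read-out strongly, whereas the one earlier single-place step, on the other aryl ring, stayed within the scatter. The two groups match in heavy atoms, in their single carbon-only aromatic ring and in hydrogen-bond donors and acceptors, so these counts do not separate them. The data shown offer no measured reason for the size of this step.

From the compounds shown here alone, it remains open whether the step belongs to the chlorines themselves or to their arrangement on the ring, and whether it would carry over to a compound with a different aryl ring on the core. Going by these compounds, how an amine or a carboxylic acid on the sulfonyl-bound aryl group would read in this assay is also open.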